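A few compounds are considered here, and "the series" means these few. Any claim that something is new, unique, unknown or untested is made for them only; others in the source may bear on it.

Of the compounds shown here, three of one shared core have been measured in a functional assay for inhibition, with Homo sapiens as the target (a lower number here means a stronger inhibitor, a higher number a weaker inhibitor), and all three returned a limit rather than a number. Compound 1 `Cc1nnc(S)n2c(C)nc(C)c12` gives > 48000 nM in this assay, which is a limit. Compound 2 `Cc1nc(C)n2c(S)nncc12` gives > 48000 nM in this assay, again a limit. Compound 3 `CSc1nncc2c(C)nc(C)n12` gives > 48000 nM in this assay, also a limit. The step from compound 1 to compound 2, a step that the two limits leave unreadable from compound 1 to compound 2, cannot be sized, and the same holds for the step from compound 2 to compound 3, a step that the two limits leave unreadable from compound 2 to compound 3, because the limit of > 48000 nM in this assay, at which 3 of the 3 values shown sit, caps every value shown. Compound 2 therefore stands at the limit of this assay, with the two neighbours shown standing at the same limit.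

Compound 4 `Cc1nc(C(C)C)n2c(S)nncc12` differs from compound 2 by isopropyl in place of methyl on an aromatic carbon. For the measured compounds named here, no measured step bears on this change, and the two steps that are known are both unreadable. Nothing in the data points to an effect beyond the scatter in either direction, and the chance that compound 4 also returns only a limit is taken to be high. The step from compound 2 to compound 4 is expected to be about a step that the limit leaves unreadable from compound 2 to compound 4. In this assay compound 4 is estimated at 70000 nM, within 20000 nM to 250000 nM.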

Compound 4, half-maximal inhibitory concentration: > 48000 nM
Compound 4: no number, only a limit; the forecaster's own chance of this, stated with the estimate: 85%; the middle value is on the limit's open side.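

Compound 4 also returns only a limit, so the step from compound 2 to compound 4, isopropyl in place of methyl on an aromatic carbon, cannot be read. The compounds shown leave open whether any change to the shared core gives a measurable inhibition, as every value stops at one ceiling: the limit of > 48000 nM in this assay, at which 4 of the 4 values shown sit.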